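The source may report more compounds than this note shows. Statements on the series, on what has been measured and on what is new or still open speak of the compounds shown alone.

Of the compounds shown here, two in this set have been tested in a functional assay on L1210 cells (Mus musculus) for inhibition, with a stated time of 48 h; on this read-out lower numbers stand for stronger inhibition and higher numbers for weaker inhibition. Compound 1, with the structure `Cc1cn(C2CC(O)C(C(=O)Nc3ccc(C(=O)CBr)cc3)O2)c(=O)[nH]c1=O`, carries a bromomethyl ketone on an amide linked to a thymidine-like core. In this assay, among the measured compounds shown here, compound 1 gives 6000 nM, the only plain number in the set. Compound 2, with the structure `Cc1cn(C2CC(O)C(CNC(=O)c3ccc(C(=O)CBr)cc3)O2)c(=O)[nH]c1=O`, differs in how the amide is attached to the sugar. For compound 2 this assay reports only a limit, > 70000 nM, which means inhibition was too weak to place a number. Thus, among the values shown, compound 1 is the one with a measurable result, while the other sits at the limit of > 70000 nM in this assay, at which 1 of the 2 values shown sits.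

Compound 3, with the structure `Cc1cn(C2CC(O)C(C(=O)Nc3ccc(C(=O)CCl)cc3)O2)c(=O)[nH]c1=O`, has not yet been measured. It differs from compound 1 only by chloro in place of bromo on a saturated chain carbon bound to a carbonyl carbon. For the measured compounds named here, no step between measured compounds bears on this change, so the expectation rests on the size of related changes. A step of a 2.5-fold higher number from compound 1 to compound 3 (0.40 log units; beyond the scatter) toward weaker inhibition is expected, modest but possibly beyond the scatter. For compound 3 the estimated value in this assay is 15000 nM, within a range from 5000 nM to 50000 nM.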

Compound 3, half-maximal inhibitory concentration: 28000 nM
Beside the measured number, compound 3's estimate is 1.9-fold (0.27 log units) below it; low and high end bracket the measured number.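

In this assay, the halogen on a saturated chain carbon bound to a carbonyl carbon is not a silent detail: chloro in place of bromo gives a 4.7-fold higher number from compound 1 to compound 3 (0.67 log units; beyond the scatter), which means weaker inhibition. Among the compounds shown here, this is the first step in the set between two measured compounds that differ in one place, and it shows that exchanging this single atom, with the rest of the structure unchanged, is enough to move the result beyond the usual scatter. Nothing shown here explains why this exchange has that effect.

The compounds shown leave open how iodo, or a hydroxyl or an amine, would fare at this same place. They also leave open whether chloro in place of bromo would have a similar effect on the differently attached amide of compound 2.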